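A few compounds are considered here, and "the series" means these few. Any claim that something is new, unique, unknown or untested is made for them only; others in the source may bear on it.

Measured so far:
- compound 1, `COc1cc(Oc2cccc(Nc3ccccc3)c2)cc(OC)c1CNCc1ccc(F)cc1`: 4220 nM
- compound 2, `COc1cc(Oc2cccc(Nc3ccccc3)c2)cc(OC)c1CNCc1ccc(C)cc1`: 13800 nM
- compound 3, `COc1cc(Oc2cccc(Nc3ccccc3)c2)cc(OC)c1CN[C@H](C)c1ccccc1`: > 20000 nM

In a functional assay on HCT-116 cells (Homo sapiens) for inhibition, read by MTT assay, with a stated time of 72 h (on this read-out lower numbers stand for stronger inhibition and higher numbers for weaker inhibition), compound 1 gives the lowest of the two numbers obtained. Compound 2 sits at a 3.3-fold higher number from compound 1 to compound 2 (0.51 log units; beyond the scatter). For compound 3 only a limit is reported, (the limit of > 20000 nM in this assay, at which 1 of the 3 values shown sits). The step from compound 1 to compound 3 is therefore an at least 4.7-fold higher number from compound 1 to compound 3 (0.67 log units; beyond the scatter), and from compound 2 to compound 3 it is an at least 1.4-fold higher number from compound 2 to compound 3 (0.16 log units; that floor lies within the scatter).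

Compound 4, `COc1cc(Oc2cccc(Nc3ccccc3)c2)cc(OC)c1CCO`, is not yet measured. Its difference from compound 1: hydroxymethyl in place of (4-fluorobenzyl)amino on a saturated chain carbon bound to an aromatic carbon. Every measured step changes only the substituent on the amine nitrogen, and each such change moves the number upward from compound 1; none removes the amine and its aromatic ring altogether, as this change does. With the shared core of compound 1 otherwise untouched, the expectation for compound 4 in this assay is a higher number, and a limit is a real possibility. The step expected is a 3.6-fold higher number from compound 1 to compound 4 (0.55 log units; beyond the scatter), giving an estimate for compound 4 of 15000 nM within 4000 nM to 50000 nM.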

Compound 4, half-maximal inhibitory concentration: > 20000 nM
Compound 4: a limit, no number; the forecaster's own chance of this, stated with the estimate: 35%; at least 1.3-fold (0.12 log units) between middle value and limit.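

Compound 4 is a limit, as compound 3 is: the limit of > 20000 nM in this assay, at which 2 of the 4 values shown sit. In this assay, the replacement of (4-fluorobenzyl)amino by hydroxymethyl on a saturated chain carbon bound to an aromatic carbon gives an at least 4.7-fold higher number from compound 1 to compound 4 (0.67 log units; beyond the scatter), and the matching change from the methyl analogue gives an at least 1.4-fold higher number from compound 2 to compound 4 (0.16 log units; that floor lies within the scatter), while the step between compound 3 and compound 4 cannot be read. Earlier steps varied only the substituent on the amine nitrogen, whereas this one shows that the shared core bearing a 2-hydroxyethyl chain does not keep the number of compound 1, so this position tolerates neither this truncation nor, as compound 3 shows, every amine substituent.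

The compounds shown do not separate the role of the amine nitrogen from that of the aromatic ring. A primary amine and a benzyl ether at this position would address each part alone.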